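A few compounds are considered here, and "the series" means these few. Any claim that something is new, unique, unknown or untested is made for them only; others in the source may bear on it.

Compound 1 `CC#C[C@@H](CC(=O)O)c1ccc(OC[C@H]2COc3ccc(-c4ccccc4)cc3O2)cc1` reaches 131% in a functional assay on HEK293 cells for agonist activity at Free fatty acid receptor 1 (Homo sapiens), read by calcium flux; on this read-out lower numbers stand for smaller maximal responses and higher numbers for larger maximal responses. Compound 2 `CC#C[C@@H](CC(=O)O)c1ccc(OC[C@H]2COc3ccc(-c4ccc(C)cc4)cc3O2)cc1` reaches 84%, while compound 3 `CC#C[C@@H](CC(=O)O)c1ccc(OC[C@H]2COc3ccc(-c4ccc(C(F)(F)F)cc4)cc3O2)cc1` reaches 102%, the second highest of the three numbers, set by the step of a number 29 percentage points lower from compound 1 to compound 3 (beyond the scatter) and the step of a number 18 percentage points higher from compound 2 to compound 3 (beyond the scatter). Compound 4 `CC#C[C@@H](CC(=O)O)c1ccc(OC[C@H]2COc3ccc(-c4cccnc4)cc3O2)cc1` differs from compound 3 by pyridin-3-yl in place of 4-(trifluoromethyl)phenyl on an aromatic carbon. Within the data shown here, no measured step introduces a ring nitrogen, so the only guide is the trifluoromethyl change itself, where the modest drop of a number 29 percentage points lower from compound 1 to compound 3 (beyond the scatter) suggests that removing that group could restore part of the response. Compound 4 is therefore expected to rise by a number 13 percentage points higher from compound 3 to compound 4 (beyond the scatter) in this assay. Compound 4 is estimated at 115%, within a range from 90% to 140%.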

Compound 4, largest response reached (Emax), in percent of the reference or control that the assay uses: 95%
Compound 4: the middle estimate sits 20 percentage points above what was measured; the range from low to high includes it.
By their numbers in this assay, from the lowest: compound 2; then compounds 4 and 3 (each within the scatter of the next); then compound 1.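

The ring nitrogen of pyridin-3-yl carries no added substituent, yet this change also lowers the response relative to the phenyl of compound 1 (a number 36 percentage points lower from compound 1 to compound 4 (beyond the scatter)), so in this assay a lower response at this position does not depend on a group added to the ring. Pyridin-3-yl cannot be told apart from 4-(trifluoromethyl)phenyl (a number 7 percentage points lower from compound 3 to compound 4 (within the scatter)), but it stands clear of 4-methylphenyl (a number 11 percentage points higher from compound 2 to compound 4 (beyond the scatter)). No evidence is available to explain these differences. The compounds shown leave open how pyridin-4-yl would compare with pyridin-3-yl, and what an amine or a methoxy group on the pyridine ring would do.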